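The source may hold more compounds than are shown below. What is called first, only, known or untested is meant among the compounds shown, and "the series" means these compounds.

Measured so far:
compound 1 `CC(C)(C)N(NC(=O)c1cccc(Cl)c1)C(=O)c1ccccc1Cl` — 155 nM
compound 2 `CCOc1cccc(C(=O)NN(C(=O)c2cc(C)cc(C)c2)C(C)(C)C)c1C` — 52.5 nM

In an assay on cells for agonist activity at ecdysone receptor (Bombyx mori), read by a luciferase reporter, with a stated time of 24 h (on this read-out lower numbers stand for an effect already at smaller amounts and higher numbers for an effect only at larger amounts of compound), compound 1 gives 155 nM, the higher of the two numbers. Compound 2 gives 52.5 nM, and the gap between the two lies beyond the scatter; the two compounds differ in several places, so no single step can be read from them. Compound 3 `CCCCCCC(=O)NN(C(=O)c1ccccc1Cl)C(C)(C)C` is not yet measured. It differs from compound 1 in one place: hexyl in place of 3-chlorophenyl on a carbonyl carbon. The measured pair offers no comparable change, so the expectation rests on the change itself. The step from compound 1 to compound 3 is expected to be a 3.9-fold higher number from compound 1 to compound 3 (0.59 log units; beyond the scatter), toward a higher number and beyond the scatter. Compound 3 is accordingly estimated at 600 nM, with a range from 150 nM to 2500 nM, the wide range reflecting the absence of any measured step of this kind.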

Compound 3, half-maximal effective concentration: 741 nM
For compound 3 the middle estimate is 1.2-fold (0.09 log units) below the measured one; measured number inside the range.
By their numbers in this assay, from the lowest: compound 2; then compound 1; then compound 3.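

In this assay, within the data shown here, the replacement of 3-chlorophenyl by hexyl on a carbonyl carbon gives a 4.8-fold higher number from compound 1 to compound 3 (0.68 log units; beyond the scatter), the first step that can be read at a single place. This position does not need a ring for a measurable effect: compound 3, which has no ring at this place, still gives 741 nM, although compound 1 keeps the lower number. Nothing available explains the size of this step.

Open, from the compounds shown here alone, is how much of the step belongs to the chlorine and how much to the ring, a question that plain phenyl at this place would address. Also open, going by these compounds, is how a shorter chain such as butyl, a longer chain such as octyl, or a hexyl chain ending in an amine would read here.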